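The compounds below may be only part of what the source reports. "The series", "measured", "known", "first", "only" and "open" are said of these compounds alone.

Measured in a functional assay (muscle tissue) with Cavia porcellus as the target; on this read-out higher numbers stand for an effect only at larger amounts of compound and lower numbers for an effect already at smaller amounts:

- Compound 1 `COC(=O)C1=C(C)N=C(C)/C(=C(\O)OC)C1c1ccccc1I` gives 46.8 nM
- Compound 2 `COC(=O)C1=C(C)N=C(C)/C(=C(\O)OC)C1c1cccc(Br)c1` gives 1.29 nM

Compound 2 stands lowest of these two. Compound 3 `CCc1ccccc1C1C(C(=O)OC)=C(C)N=C(C)/C1=C(\O)OC` differs from it as follows: 2-ethylphenyl in place of 3-bromophenyl on a saturated ring carbon, with 2-ethylphenyl in place of 3-bromophenyl on a saturated ring carbon. Within the data shown here, the one measured step bearing on this is a 36-fold lower number from compound 1 to compound 2 (1.56 log units; beyond the scatter), a large one, with 3-bromophenyl in place of 2-iodophenyl. Since 2-ethylphenyl now leaves 3-bromophenyl behind, a step of similar size toward a higher number is expected in this assay, although no ethyl group has been measured. The expected change is a 23-fold higher number from compound 2 to compound 3 (1.37 log units; beyond the scatter). Compound 3 is estimated at 30 nM, within an expected range of 6 nM to 150 nM.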

Compound 3, half-maximal effective concentration: 6.46 nM
Beside the measured number, compound 3's estimate is 4.6-fold (0.67 log units) above it; the measured number falls inside the stated range.
By their numbers in this assay, from the lowest: compound 2; then compound 3; then compound 1.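

In this assay, the group on the saturated ring carbon proves sensitive to what sits on the aromatic carbon alone: with the place kept, ethyl in place of iodo gives a 7.2-fold lower number from compound 1 to compound 3 (0.86 log units; beyond the scatter). Earlier, group and place had changed together, and 2-ethylphenyl still does not match 3-bromophenyl, with a 5.0-fold higher number from compound 2 to compound 3 (0.70 log units; beyond the scatter). Nothing measured here accounts for either shift.

On these data alone, how much of that gap belongs to the place and how much to the group stays open. A 3-ethylphenyl group or a nitro group on that ring would bear on this.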